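Cyclopropylcarbonyl to (sec-butyl)carbonyl on the shared core

A few compounds are considered here, and "the series" means these few. Any claim that something is new, unique, unknown or untested is made for them only; others in the source may bear on it.

Measured compounds:
- compound 1, `O=C(CC1CCN(C(=O)C2CC2)CC1)Nc1ccc(OC(F)(F)F)c(F)c1`: 715 ug/mL
- compound 2, `Cc1ccoc1C(=O)N1CCC(NC(=O)Nc2ccc(OC(F)(F)F)cc2)CC1`: 0.92 ug/mL
- compound 3, `CCC(=O)N1CCC(NC(=O)Nc2ccc(OC(F)(F)F)c(F)c2)CC1`: 11 ug/mL

In a physicochemical assay for solubility, read by mass spectrometry, in phosphate buffer, with a stated time of 24 h, at pH 7.4 (on this read-out lower numbers stand for lower solubility and higher numbers for higher solubility), compound 1 gives 715 ug/mL, the highest of the three numbers. The nearest number is that of compound 3, which gives 11 ug/mL in this assay; the furthest is compound 2, which gives 0.92 ug/mL. Both gaps to compound 1 lie beyond the scatter. No pair of these compounds differs in a single place, so no step between measured compounds can be read off.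

The next compound is compound 4, `CC[C@H](C)C(=O)N1CCC(CC(=O)Nc2ccc(OC(F)(F)F)c(F)c2)CC1`, not yet measured in this assay. It differs from compound 1 in one place: sec-butyl in place of cyclopropyl on a carbonyl carbon. The ring-bearing group is replaced by an open chain of four carbons with one defined stereocentre, on the carbonyl carbon that also bears the amide-type nitrogen in the ring.

With no measured step of this kind in the set, the expectation rests on compound 1 alone. A small move downward is expected, close to the edge of the scatter; the expected step is a 2.4-fold lower number from compound 1 to compound 4 (0.38 log units; beyond the scatter). For compound 4 in this assay the estimate is 300 ug/mL, with a range from 100 ug/mL to 700 ug/mL, and the value should be reported as a number rather than a limit, given the number seen for compound 1 at 715 ug/mL.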

Compound 4, solubility: 21 ug/mL
For compound 4 the middle estimate is 14-fold (1.15 log units) above the measured one; measured number outside the range, below it.
By their numbers in this assay, from the lowest: compound 2; then compounds 3 and 4 (each within the scatter of the next); then compound 1.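

Within the data shown here, the first matched step lies on a carbonyl carbon whose other neighbour is an amide-type nitrogen in a ring: in this assay, sec-butyl in place of cyclopropyl gives a 34-fold lower number from compound 1 to compound 4 (1.53 log units; beyond the scatter), a large step for one change on the shared core. The number at this position is therefore not indifferent to the group placed there, and compound 4, at 21 ug/mL, does not keep the high number of compound 1. The step covers the whole swap, in which the ring is lost, the carbon count changes and a defined stereocentre enters, and nothing shown indicates why the number falls so far.

Which of these differences carries the step stays open: cyclobutyl, isopropyl and the opposite sec-butyl stereoisomer on the same carbonyl would begin to separate them. Also open, from the compounds shown here alone, is how an amine or a carboxylic acid on this group would read in this assay, and whether the same swap gives a step of similar size on another core.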